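Swapping the aryl group on the triazole nitrogen

The compounds below may be only part of what the source reports. "The series", "measured", "known", "first", "only" and "open" are said of these compounds alone.

Measured compounds:
Compound 1, `COc1cc(/C=C/C(C)=O)ccc1OCc1cn(-c2c(F)cccc2F)nn1`, gives 2030 nM in a functional assay on MCF7 cells (Homo sapiens) for antiproliferative activity, read by MTT assay, with a stated time of 48 h; a lower number here means a stronger inhibitor, a higher number a weaker inhibitor.
Compound 2, `COc1cc(/C=C/C(C)=O)ccc1OCc1cn(-c2ccccc2CO)nn1`, gives 65800 nM in this assay.
Compound 3, `COc1ccc(-n2cc(COc3ccc(/C=C/C(C)=O)cc3OC)nn2)cc1`, gives 33700 nM in this assay.

Compound 2 has the highest number of the three, so it is the weakest inhibitor in this set; its nearest neighbour is compound 3, by a 2.0-fold lower number from compound 2 to compound 3 (0.29 log units; within the scatter), while the furthest gap is a 32-fold higher number from compound 1 to compound 2 (1.51 log units; beyond the scatter). The unmeasured compound 4, `COc1cccc(-n2cc(COc3ccc(/C=C/C(C)=O)cc3OC)nn2)c1`, differs from compound 2 by one change: 3-methoxyphenyl in place of 2-(hydroxymethyl)phenyl on an aromatic nitrogen.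

For the measured compounds named here, two measured steps bear on this. The step from compound 2 to compound 3 exchanges the same leaving group for a related methoxyphenyl, and is within the scatter. The step from compound 1 to compound 3, a 17-fold higher number from compound 1 to compound 3 (1.22 log units; beyond the scatter), shows that a methoxyphenyl here sits far from compound 1. Compound 4 is therefore expected to land near compound 3, a step of a 2.2-fold lower number from compound 2 to compound 4 (0.34 log units; beyond the scatter) from compound 2, which is not expected to exceed the scatter by much. The estimate for compound 4 is 30000 nM, within a range of 9000 nM to 100000 nM.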

Compound 4, half-maximal inhibitory concentration: 1800 nM
Beside the measured number, compound 4's estimate is 17-fold (1.22 log units) above it, and the stated range ends above it.
By their numbers in this assay, from the lowest: compounds 4 and 1 (each within the scatter of the next); then compounds 3 and 2 (each within the scatter of the next).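

Position on the phenyl ring matters here: with 3-methoxyphenyl in place of 4-methoxyphenyl, this assay shows a 19-fold lower number from compound 3 to compound 4 (1.27 log units; beyond the scatter), so two groups of the same size and atom count can give very different results on this triazole nitrogen. The change from 2-(hydroxymethyl)phenyl is just as clearly beyond the scatter, at a 37-fold lower number from compound 2 to compound 4 (1.56 log units; beyond the scatter), while a 1.1-fold lower number from compound 1 to compound 4 (0.05 log units; within the scatter) leaves the 3-methoxyphenyl and 2,6-difluorophenyl groups within the scatter of each other, so a group without fluorine can do as well as the difluorinated one. Nothing available explains why the 3-methoxyphenyl and 4-methoxyphenyl groups differ so sharply.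

The compounds shown leave open whether the methoxy oxygen itself matters, or whether an amine, a carboxylic acid or a longer ethoxy chain in its place would hold this level. They also do not show how 2-methoxyphenyl would compare.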